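The compounds below may be only part of what the source reports. "The series", "measured", "known", "first", "only" and "open" are said of these compounds alone.

Compound 1 `O=C(Nc1ccc(I)cc1)N[C@H]1CC[C@H](Oc2ccc(F)cc2)CC1` gives 10200 nM in a functional assay on CRL2813 cells (Homo sapiens) for cytotoxicity, read by sulforhodamine B assay, with a stated time of 5 days; a lower number here means a stronger inhibitor, a higher number a weaker inhibitor. Compound 2 `O=C(Nc1ccc(Cl)cc1)N[C@H]1CC[C@H](Oc2ccc(F)cc2)CC1` gives only the assay limit, > 20000 nM.

Compound 2 therefore stands at the limit of this assay (the limit of > 20000 nM in this assay, at which 1 of the 2 values shown sits), without a number of its own. For the measured compounds named here, the one measured step, an at least 1.9-fold higher number from compound 1 to compound 2 (0.29 log units; that floor lies within the scatter), runs up to that limit and its floor lies within the scatter. Compound 3 `COc1cccc(NC(=O)N[C@H]2CC[C@H](Oc3ccc(F)cc3)CC2)c1` differs from compound 2 by 3-methoxyphenyl in place of 4-chlorophenyl on an amide-type nitrogen. Going by the values given here, no measured step covers this change, so no direction beyond the scatter is expected. The resulting step is estimated as a number no higher from compound 2 to compound 3 (the limit leaves the size open). For compound 3 the expected value is 20000 nM, with a range from 6000 nM to 60000 nM.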

Compound 3, half-maximal inhibitory concentration: 14000 nM
Compound 3: the middle estimate sits 1.4-fold (0.15 log units) above what was measured, within the range that was stated.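

In this assay, 3-methoxyphenyl on the amide-type nitrogen gives a second measured number, and the step against 4-iodophenyl is a 1.4-fold higher number from compound 1 to compound 3 (0.14 log units; within the scatter), so these two groups cannot be told apart here. Going by these compounds, the step against 4-chlorophenyl is an at least 1.4-fold lower number from compound 2 to compound 3 (0.15 log units; that floor lies within the scatter), and its true size stays open. Compound 2 has no number of its own, only a limit: the limit of > 20000 nM in this assay, at which 1 of the 3 values shown sits.

On these data alone, whether any group at this position can move the number beyond the scatter remains open. A carboxylic acid or an amine on the aromatic ring would be one such test.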